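The source may report more compounds than this note shows. Statements on the series, on what has been measured and on what is new or still open speak of the compounds shown alone.

Compound 2 `O=c1ccoc2cc(OCc3cn(Cc4cccc(F)c4)nn3)ccc12` is the starting point here. In an ADME assay on L02 cells (Homo sapiens) for cytotoxicity, read by MTT assay, with a stated time of 48 h (on this read-out higher numbers stand for weaker inhibition and lower numbers for stronger inhibition), compound 2 gives > 300000 nM, which is a limit of the assay rather than a measured number. Compound 1 `O=c1ccoc2cc(OCc3cn(Cc4ccc(Cl)cc4Cl)nn3)ccc12` differs from it only by carrying 2,4-dichlorophenyl in place of 3-fluorophenyl on the saturated chain carbon bound to an aromatic nitrogen. In this assay compound 1 gives > 300000 nM, again a limit of the assay. The step that the two limits leave unreadable from compound 1 to compound 2 therefore stays unreadable, because both values sit at the limit of > 300000 nM in this assay, at which 2 of the 2 values shown sit. Compound 3 `O=c1ccoc2cc(OCc3cn(Cc4ccc([N+](=O)[O-])cc4)nn3)ccc12` has not yet been measured; its change from compound 2 is 4-nitrophenyl in place of 3-fluorophenyl on a saturated chain carbon bound to an aromatic nitrogen. Among the measured compounds shown here, the only measured step touching a swap of the aryl group at this position gives no direction and no size, so nothing points toward a change. Compound 3 is therefore expected to remain at the same limit, an estimated step that the limit leaves unreadable from compound 2 to compound 3. The estimate for compound 3 is 400000 nM, with a range from 200000 nM to 1000000 nM.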

Compound 3, half-maximal inhibitory concentration: > 300000 nM
Compound 3 ended at the assay's limit; the forecaster's own chance of this, stated with the estimate: 85%; the middle value is on the limit's open side.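

Compound 3 adds no readable step from compound 1 or compound 2, because all three compounds stop at the same limit of the assay: the limit of > 300000 nM in this assay, at which 3 of the 3 values shown sit.
The compounds shown leave open whether any of these aryl groups changes the result in this assay, and by how much.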